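This account rests on a few compounds, and the source may have more. Where it says the series, first, only, none or still open, it means among the compounds named here.

For the measured compounds named here, compound 1 `COc1ccc(-c2nc3cc(Cl)c(Cl)cc3[nH]2)cc1` gives 18000 nM in an ADME assay on BHK cells (Mesocricetus auratus) for cytotoxicity, read by MTT assay, with a stated time of 96 h (on this read-out lower numbers stand for higher toxicity in this test and higher numbers for lower toxicity in this test), the lowest of the three numbers measured so far. Compound 2 `Nc1ccc(-c2nc3cc(Cl)c(Cl)cc3[nH]2)cc1` gives 30000 nM in this assay, and compound 3 `Oc1ccc(-c2nc3cc(Cl)c(Cl)cc3[nH]2)cc1` gives 29000 nM. The steps of a 1.7-fold higher number from compound 1 to compound 2 (0.22 log units; within the scatter) and a 1.6-fold higher number from compound 1 to compound 3 (0.21 log units; within the scatter), like a 1.0-fold lower number from compound 2 to compound 3 (0.01 log units; within the scatter), all lie within the scatter. Compound 4 `COc1ccc(-c2nc3cc(Cl)c(Cl)cc3[nH]2)c([N+](=O)[O-])c1` differs from compound 1 by nitro in place of hydrogen on an aromatic carbon. Going by the values given here, none of the measured steps involves a nitro group; each exchanges the methoxy group for another group, so none bears directly on this change. No step beyond the scatter is therefore expected in this assay: the estimated step is no change at the digits printed from compound 1 to compound 4 (within the scatter), and compound 4 is expected to give 18000 nM, with a range from 6000 nM to 50000 nM.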

Compound 4, half-maximal cytotoxic concentration: 80000 nM
Estimate against measurement, compound 4: 4.4-fold (0.65 log units) below; measured number above the stated range.
By their numbers in this assay, from the lowest: compounds 1, 3 and 2 (each within the scatter of the next); then compound 4.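

At this position, ortho to a large group and meta to a methoxy group, nitro in place of hydrogen gives a 4.4-fold higher number from compound 1 to compound 4 (0.65 log units; beyond the scatter) in this assay. This is the first step shown to lie beyond the scatter, so the ring carbon that carries the nitro group can shift the number where the exchanges of the methoxy group did not. Nothing available explains this step.

On these data alone, whether a nitrile or a carboxylic acid at the same carbon would shift the number likewise remains open. So does whether nitro would do so elsewhere on this ring.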